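Swapping a branched chain for a ring on the guanidine nitrogen

The source may hold more compounds than are shown below. What is called first, only, known or untested is meant among the compounds shown, and "the series" means these compounds.

Compound 1 `CCC(C)(C)/N=C(\NC#N)Nc1cc(C(F)(F)F)cc(C(F)(F)F)c1` and compound 3 `CCC(C)(C)/N=C(\NC#N)Nc1cc(Cl)cc(Cl)c1` carry the same 1,1-dimethylpropyl group on a double-bonded nitrogen but differ in their cores; the difference between the two cores is not broken down here. In a functional assay (aorta) with Rattus norvegicus as the target (on this read-out higher numbers stand for weaker inhibition and lower numbers for stronger inhibition), compound 1 gives 900 nM. In this assay compound 3 gives 300 nM, the lower of the two numbers.

Compound 2 `N#CN/C(=N\C1CCCC1)Nc1cc(C(F)(F)F)cc(C(F)(F)F)c1` arises from compound 1 through (cyclopentyl in place of 1,1-dimethylpropyl on a double-bonded nitrogen). In this assay compound 2 reaches only the limit of > 300000 nM, which is a boundary of the measurement rather than a number. This gives an at least 330-fold higher number from compound 1 to compound 2 (2.52 log units; beyond the scatter), a step resting on (the limit of > 300000 nM in this assay, at which 1 of the 3 values shown sits).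

Compound 4 `N#CN/C(=N\C1CCCC1)Nc1cc(Cl)cc(Cl)c1` stands to compound 3 exactly as compound 2 stands to compound 1: it arises through (cyclopentyl in place of 1,1-dimethylpropyl on a double-bonded nitrogen), the same change at the same place. Only compound 1 and compound 2 show what this change does, and there it erased measurable activity. Since compound 3 starts from a lower number than compound 1, the expected result for compound 4 is a weaker inhibition by a large margin, estimated as a 670-fold higher number from compound 3 to compound 4 (2.82 log units; beyond the scatter), with a fair chance that only a limit is reported again. The expected value for compound 4 in this assay is 200000 nM, within a range from 30000 nM to 1000000 nM.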

Compound 4, half-maximal inhibitory concentration: 75000 nM
Beside the measured number, compound 4's estimate is 2.7-fold (0.43 log units) above it, within the range that was stated.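

Putting cyclopentyl in place of 1,1-dimethylpropyl on a double-bonded nitrogen also costs a great deal of inhibition on the second core in this assay, with a 250-fold higher number from compound 3 to compound 4 (2.40 log units; beyond the scatter), so the change goes the same way and is large on both cores: the same change on two cores in this assay, an at least 330-fold higher number (2.52 log units; beyond the scatter) from compound 1 to compound 2 and a 250-fold higher number (2.40 log units; beyond the scatter) from compound 3 to compound 4; the limit leaves it open whether they differ

As far as these compounds go, compound 2 gives > 300000 nM, which is a limit of the assay and not a number, so the true size of the step on the core of compound 1 is unknown and neither core can be said to lose more than the other.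

Among these compounds, two cores are only two examples: they show that the change carried over once, but not that it would do so on every other core, and they do not explain why the loss is so large.

The compounds shown place only these two groups on that nitrogen, so it remains open whether the loss follows from the ring itself or from losing the open, branched chain, a question that a tert-butyl group, a cyclohexyl ring or a longer chain such as n-hexyl could help to answer. From the compounds shown here alone, it is also open whether the same loss would appear on a core carrying methoxy or methyl groups instead of chlorine or trifluoromethyl.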